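The source may report more compounds than this note shows. Statements on the series, on what has been measured and on what is new or still open speak of the compounds shown alone.

Three compounds share one core and differ only in the group on the outer six-membered ring. Compound 1 `C/C(=C\c1cc(-c2ccc(C)cc2)cs1)C(N)=O` carries a methyl there, compound 2 `C/C(=C\c1cc(-c2ccc(F)cc2)cs1)C(N)=O` a fluoro, and compound 3 `C/C(=C\c1cc(-c2ccc(S(C)(=O)=O)cc2)cs1)C(N)=O` a methylsulfonyl. In a functional assay on BGC-823 cells (Homo sapiens) for cytotoxicity, read by CCK-8 assay, with a stated time of 24 h (a higher number here means a weaker inhibitor, a lower number a stronger inhibitor), compound 1 reaches only the limit of the assay, > 50000 nM. In this assay compound 2 likewise gives only the limit, > 50000 nM. Compound 3 too gives only the limit in this assay, > 50000 nM. Because every value shown sits at this limit (the limit of > 50000 nM in this assay, at which 3 of the 3 values shown sit), the steps cannot be sized: a step that the two limits leave unreadable from compound 1 to compound 2, a step that the two limits leave unreadable from compound 1 to compound 3 and a step that the two limits leave unreadable from compound 2 to compound 3 all stay unreadable. So compound 3 stands at the limit, with no number of its own.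

Compound 4 `C/C(=C\c1cc(-c2ccc([N+](=O)[O-])cc2)cs1)C(N)=O` differs from compound 3 by one exchange, (nitro in place of methylsulfonyl on an aromatic carbon). Going by the values given here, no measured step bears on this change in a readable way; all three neighbours sit at the limit. The expectation for compound 4 in this assay is therefore a value that again stays at or past the limit, meaning a step that the limit leaves unreadable from compound 3 to compound 4. Compound 4 is estimated at 80000 nM, within 20000 nM to 300000 nM.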

Compound 4, half-maximal inhibitory concentration: > 50000 nM
Compound 4 gave a limit, no number (the forecaster's own chance of this, stated with the estimate: 80%); the middle value does not contradict the limit.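

No new step can be read: compound 1, compound 2, compound 3 and compound 4 each give only a limit in this assay, not a number, so their differences stay unsized: the limit of > 50000 nM in this assay, at which 4 of the 4 values shown sit.

The compounds shown leave open how these four groups would rank, and whether any group at this place gives a measurable value.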